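Amide substitution and clearance in a benzoxazole thioether series

The compounds below may be only part of what the source reports. "The series", "measured", "known", "first", "only" and "open" are said of these compounds alone.

The compounds share a core, shown for compound 1 as `O=C(CCSc1nc2cc(Cl)ccc2o1)N1CCCCC1`, with changes at the amide. In an ADME assay on microsomes from liver (Mus musculus) for metabolic stability, read by LC-MS, using NADPH, with a stated time of 45 min, tested at 0.5 uM (a lower number here means slower removal, a higher number faster removal of the compound), compound 1 gives 128 mL/min/g. For compound 2, `O=C(CCSc1nc2cc(Cl)ccc2o1)NC1CCCC1`, the entry in this assay reads "not determined" (no result reported), so no number is reported for it. Compound 3, `CCN(CC)C(=O)CCSc1nc2cc(Cl)ccc2o1`, gives 108 mL/min/g in this assay, the lowest of the two numbers; its nearest neighbour is compound 1, and the step of a 1.2-fold lower number from compound 1 to compound 3 (0.07 log units; within the scatter) stays within the scatter, so the two cannot be ordered.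

Compound 4, `CN1CCN(C(=O)CCSc2nc3cc(Cl)ccc3o2)CC1`, differs from compound 3 as follows: 4-methylpiperazin-1-yl in place of diethylamino on a carbonyl carbon. Within the data shown here, the only measured step at this position, a 1.2-fold lower number from compound 1 to compound 3 (0.07 log units; within the scatter), exchanged one nitrogen substituent for another without a change beyond the scatter. Among the measured compounds shown here, no measured compound carries the entering group, so the data give no basis for a direction. Compound 4 is therefore expected to show a 1.1-fold lower number from compound 3 to compound 4 (0.03 log units; within the scatter) in this assay, a step not beyond the scatter. The estimate for compound 4 in this assay is 100 mL/min/g, with a range from 45 mL/min/g to 220 mL/min/g.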

Compound 4, intrinsic clearance in a liver preparation (reported as CLH), per the amount of preparation that the assay uses: 41.5 mL/min/g
The estimate for compound 4 lay 2.4-fold (0.38 log units) above the measured number; the whole stated range lies above it.
By their numbers in this assay, from the lowest: compound 4; then compounds 3 and 1 (each within the scatter of the next).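

In this assay, among these compounds, the group on the carbonyl carbon turns out to be able to move the number beyond the scatter, which the one earlier step at this position did not show: 4-methylpiperazin-1-yl in place of diethylamino gives a 2.6-fold lower number from compound 3 to compound 4 (0.42 log units; beyond the scatter), and 4-methylpiperazin-1-yl in place of piperidin-1-yl gives a 3.1-fold lower number from compound 1 to compound 4 (0.49 log units; beyond the scatter). Both steps point the same way, and they start from two compounds that cannot be ordered against each other. Nothing available explains why the number falls with this group.

As far as these compounds go, what a morpholin-4-yl or an unsubstituted piperazin-1-yl would give on the same carbonyl carbon remains open, and with it which part of the entering group goes with the lower number. Also open, from the compounds shown here alone, is whether the lower number would hold with a longer saturated chain on the carbonyl carbon.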